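A few compounds are considered here, and "the series" means these few. Any claim that something is new, unique, unknown or untested is made for them only; others in the source may bear on it.

Measured compounds:
Compound 1 `CCCC(=O)OCc1ccc2oc(=O)c(C(=O)Oc3cccc(Br)c3)cc2c1`: 50.5%
Compound 2 `CCCCC(=O)OCc1ccc2oc(=O)c(C(=O)Oc3cccc(Br)c3)cc2c1`: 63.3%
Compound 3 `O=C(Oc1cccc(Br)c1)c1cc2cc([N+](=O)[O-])ccc2oc1=O`: 35.2%

In a functional assay on HT-1080 cells (Homo sapiens), read by transwell migration, with a stated time of 24 h, tested at 1 uM (on this read-out higher numbers stand for a weaker effect at the one concentration tested and lower numbers for a stronger effect), compound 3 stands lowest of the three, with the strongest effect. Compound 4 `NCc1ccc2oc(=O)c(C(=O)Oc3cccc(Br)c3)cc2c1` is not yet measured; it differs from compound 3 by aminomethyl in place of nitro on an aromatic carbon. For the measured compounds named here, no measured step swaps nitro for aminomethyl, so the guide is indirect: a number 15.3 percentage points lower from compound 1 to compound 3 (beyond the scatter) and a number 28.1 percentage points lower from compound 2 to compound 3 (beyond the scatter) show that exchanging either ester-bearing group for nitro lowered the number by a modest amount, while a number 12.8 percentage points higher from compound 1 to compound 2 (beyond the scatter) shows a modest rise for a small chain change. Leaving nitro for a different, smaller group is therefore expected to move the number back upward, to roughly the range of compound 1, though with wide uncertainty. Compound 4 is estimated at 50%, between 30% and 72%, a step of a number 14.8 percentage points higher from compound 3 to compound 4 (beyond the scatter).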

Compound 4, a percentage reported as activity, at one concentration (the size of the read-out at that concentration, not a potency): 79.3%
Compound 4: the middle estimate sits 29.3 percentage points below what was measured; the measured number lies above the stated range.
By their numbers in this assay, from the lowest: compound 3; then compound 1; then compound 2; then compound 4.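

In this assay, for the compounds shown here, aminomethyl in place of nitro on this aromatic carbon gives a number 44.1 percentage points higher from compound 3 to compound 4 (beyond the scatter) and is the only step here printed as large, so this position responds strongly to the group it carries. Amino in place of either ester group on the saturated carbon also raises the number, with a number 16 percentage points higher from compound 2 to compound 4 (beyond the scatter) and with a number 28.8 percentage points higher from compound 1 to compound 4 (beyond the scatter) as well, leaving compound 4 with the weakest effect of the four. Nothing measured here explains these shifts.

Still open, on these data alone, is whether a dimethylamine or an acetamide on that same saturated carbon would behave like the free amine of compound 4 or like the esters. A carboxylic acid placed directly on the aromatic carbon would show whether the low number of compound 3 is particular to nitro.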